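Compound 2 to compound 3: trifluoromethyl for methyl

A few compounds are considered here, and "the series" means these few. Any claim that something is new, unique, unknown or untested is made for them only; others in the source may bear on it.

Measured in an ADME assay on BHK-21 cells (Mesocricetus auratus) for cytotoxicity, read by MTT assay, with a stated time of 72 h; a higher number here means that more compound is tolerated, a lower number that less compound is tolerated:
- compound 1 `FC(F)(F)c1ccc(-c2nn(-c3ccccc3)cc2CNc2ccc(Cl)cc2)cc1` gives 31000 nM
- compound 2 `Cc1ccc(-c2nn(-c3ccccc3)cc2CNc2ccc(Br)cc2)cc1` gives > 100000 nM (a limit)

Compound 2 stands in the series only as a limit, > 100000 nM, and not as a number. Compound 3 `FC(F)(F)c1ccc(-c2nn(-c3ccccc3)cc2CNc2ccc(Br)cc2)cc1` follows from compound 2 with trifluoromethyl in place of methyl on an aromatic carbon. Among the measured compounds shown here, no pair of measured compounds shows this change on its own. For the measured compounds named here, compound 1 also carries trifluoromethyl and gives 31000 nM, the only true number so far. On that basis, less compound is expected to be tolerated in this assay, and the estimated size is an at least 2.8-fold lower number from compound 2 to compound 3 (0.45 log units; beyond the scatter). Compound 3 is estimated at 35000 nM, with an expected range of 12000 nM to 100000 nM.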

Compound 3, half-maximal cytotoxic concentration: 28000 nM
Compound 3: the middle estimate sits 1.3-fold (0.10 log units) above what was measured; measured number inside the range.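

In this assay the change from 4-methylphenyl to 4-(trifluoromethyl)phenyl now stands alone in one pair, as an at least 3.5-fold lower number from compound 2 to compound 3 (0.55 log units; beyond the scatter). Compound 2 is a limit and not a number, so this step has a bound but no exact size: the limit of > 100000 nM in this assay, at which 1 of the 3 values shown sits. With trifluoromethyl held in place, bromo in place of chloro gives a 1.1-fold lower number from compound 1 to compound 3 (0.04 log units; within the scatter), so that change does not separate these two compounds.

The compounds shown leave open whether the lower number is particular to trifluoromethyl or would also appear with another group at this place, such as a nitrile, a methoxy or an amine. They also leave open whether the change from methyl to trifluoromethyl reads the same with chloro in place of bromo.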